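Replacing Bromo with Methoxyphenyl on a Sulfonyl Aryl

This account rests on a few compounds, and the source may have more. Where it says the series, first, only, none or still open, it means among the compounds named here.

Compound 1 `Cc1noc(C)c1S(=O)(=O)N1CCC(N2CCC(C)CC2)CC1` — in a functional assay on DLD-1 cells (Homo sapiens) for antiproliferative activity, read by CellTiter-Glo, with a stated time of 72 h (on this read-out lower numbers stand for stronger inhibition and higher numbers for weaker inhibition), compound 1 gives only a limit of the assay, > 5000 nM.
Compound 2 `CC1CCN(C2CCN(S(=O)(=O)c3ccccc3Br)CC2)CC1` — in this assay compound 2 gives 3 nM.
Compound 3 `Cc1nc(Cl)sc1S(=O)(=O)N1CCC(N2CCC(C)CC2)CC1` — in this assay compound 3 gives 1.6 nM.

Of the two real numbers, compound 2 has the higher one, yet a 1.9-fold lower number from compound 2 to compound 3 (0.27 log units; within the scatter) stays within the scatter, so the two cannot be ranked. The remaining value sits at the limit of > 5000 nM in this assay, at which 1 of the 3 values shown sits.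

Compound 4 `COc1ccc(-c2ccccc2S(=O)(=O)N2CCC(N3CCC(C)CC3)CC2)cc1` carries 4-methoxyphenyl in place of bromo on an aromatic carbon. For the measured compounds named here, the steps of an at least 1600-fold lower number from compound 1 to compound 2 (3.22 log units; beyond the scatter) and an at least 3100-fold lower number from compound 1 to compound 3 (3.49 log units; beyond the scatter) show that the aryl group on the sulfonyl sulfur governs potency, but no measured step exchanges one substituent on that ring for a second ring. The size of the effect is therefore open; a weakening is expected, a 10-fold higher number from compound 2 to compound 4 (1.00 log units; beyond the scatter). Compound 4 is estimated at 30 nM, between 3 nM and 500 nM.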

Compound 4, half-maximal inhibitory concentration: 1000 nM
For compound 4 the middle estimate is 33-fold (1.52 log units) below the measured one; measured number above the stated range.
By their numbers in this assay, from the lowest: compounds 3 and 2 (each within the scatter of the next); then compound 4. At a limit, above all of these: compound 1.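

For the compounds shown here, until this point, only whole aryl groups on the sulfonyl sulfur had been exchanged; compound 4 is the first to change a single substituent on that ring. In this assay, 4-methoxyphenyl in place of bromo gives a 330-fold higher number from compound 2 to compound 4 (2.52 log units; beyond the scatter), so this place, ortho to a large group, does not accept every substituent. Nothing measured here explains the loss. Open, on these data alone, is whether a small group such as methyl or chloro would hold the potency of compound 2, and whether plain phenyl would behave like 4-methoxyphenyl.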